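The compounds below may be only part of what the source reports. "The series", "measured", "known", "first", "only" and "open" are said of these compounds alone.

Compound 1 `Oc1ccc(-c2nnc(Nc3ncccn3)o2)cc1` carries a hydroxy group on its outer six-membered ring. In a functional assay, with a stated time of 30 min, tested at 20 uM (a higher number here means more inhibition at the concentration tested (going by the name of the read-out), a lower number less inhibition), compound 1 gives 63.4%. Compound 2 `Oc1ccccc1-c1nnc(Nc2ncccn2)o1` is made of the same atoms joined differently; the difference between the two cores is not broken down here. In this assay compound 2 gives 58.8%, which lies within the scatter of the number for compound 1. Compound 3 `Clc1ccc(-c2nnc(Nc3ncccn3)o2)cc1` differs from compound 1 by a single swap (chloro in place of hydroxy on an aromatic carbon). In this assay compound 3 gives 46.2%, and the swap itself made the step of a number 17.2 percentage points lower from compound 1 to compound 3 (beyond the scatter).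

Compound 4 `Clc1ccccc1-c1nnc(Nc2ncccn2)o1` has not yet been measured. It arises from compound 2 through (chloro in place of hydroxy on an aromatic carbon). This is the same kind of change as that from compound 1 to compound 3, but not the same one: there the place was para to a large group, here it is ortho to a large group. Because the earlier change made a number 17.2 percentage points lower from compound 1 to compound 3 (beyond the scatter), a step of similar size is expected here, so compound 4 is estimated to sit at 42%, between 28% and 56%. Expected, then, for compound 4 is the step of a number 16.8 percentage points lower from compound 2 to compound 4 (beyond the scatter).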

Compound 4, a percentage reported as inhibition, at one concentration (the size of the read-out at that concentration, not a potency): < 20%
Compound 4 was reported as a limit (the forecaster's own chance of this, stated with the estimate: 5%); at least 22 percentage points between middle value and limit.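

Chloro in place of hydroxy on an aromatic carbon lowers the number on both cores, but the size of the step does not carry over from one core to the other, since in this assay the second case is a number at least 38.8 percentage points lower from compound 2 to compound 4 (beyond the scatter), and the two steps differ: the same change on two cores in this assay, a number 17.2 percentage points lower (beyond the scatter) from compound 1 to compound 3 and a number at least 38.8 percentage points lower (beyond the scatter) from compound 2 to compound 4, at least 21.6 percentage points apart, beyond the scatter of two such steps

Compound 4 stands at < 20%, which is a limit of the assay and not a number: the limit of < 20% in this assay, at which 1 of the 4 values shown sits.

These two pairs do not show whether the larger step belongs to the place of the change, here ortho to a large group, or to something else that separates the two cores, and they set no rule for the wider series.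

The compounds shown leave open how other groups at these places would compare, such as a methoxy group, an amine or a carboxylic acid. Each number is also a read-out at one concentration, so the potency of these compounds remains open as well.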